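A few compounds are considered here, and "the series" means these few. Any claim that something is new, unique, unknown or untested is made for them only; others in the source may bear on it.

Series notes. Compound 1 `Nc1nc(Cl)nc2c1ncn2C1C(O)C(O)[C@@]2(COP(=O)(O)OP(=O)(O)OP(=O)(O)O)C[C@@H]12` in an assay on cells with P2Y purinoceptor 1 (Homo sapiens) as the target, read by inositol phosphate accumulation (on this read-out lower numbers stand for an effect already at smaller amounts and higher numbers for an effect only at larger amounts of compound), gives 7 nM. Going by the values given here, compound 2 `CNc1ncnc2c1ncn2C1C(O)C(O)[C@@]2(COP(=O)(O)OP(=O)(O)OP(=O)(O)O)C[C@@H]12` in this assay gives 33 nM, the highest of the two numbers so far; the only measured step, a 4.7-fold higher number from compound 1 to compound 2 (0.67 log units; beyond the scatter), changes two places at once, exchanging the group on the saturated ring carbon as a whole. Compound 3 `CNc1nc(Cl)nc2c1ncn2C1C(O)C(O)[C@@]2(COP(=O)(O)OP(=O)(O)OP(=O)(O)O)C[C@@H]12` differs from compound 2 by chloro in place of hydrogen on an aromatic carbon, with the methylamino group of compound 2 retained. Among the compounds with values here, no measured step isolates the chloro alone; compound 3 combines the chloro of compound 1 with the methylamino group of compound 2, so it sits between the two measured structures. From the size of the step between compound 1 and compound 2, the chloro is expected to carry part of that difference, so a modest step toward a lower number, a 2.8-fold lower number from compound 2 to compound 3 (0.44 log units; beyond the scatter), is expected for compound 3. The estimate for compound 3 is 12 nM, within 4 nM to 35 nM.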

Compound 3, half-maximal effective concentration: 9 nM
Compound 3: middle estimate off by 1.3-fold (0.12 log units), on the high side; low and high end bracket the measured number.
By their numbers in this assay, from the lowest: compounds 1 and 3 (each within the scatter of the next); then compound 2.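

In this assay, chloro in place of hydrogen on an aromatic carbon, between two ring nitrogen atoms, is now read as a single change, and the step lies beyond the scatter (a 3.7-fold lower number from compound 2 to compound 3 (0.56 log units; beyond the scatter)). With the chloro present, methyl in place of hydrogen on a nitrogen on an aromatic ring gives no separable difference (a 1.3-fold higher number from compound 1 to compound 3 (0.11 log units; within the scatter)), so compound 1 and compound 3 cannot be told apart here. Nothing available explains either step.

Open, from the compounds shown here alone, is whether bromo, methoxy or an amine on the same aromatic carbon would give a step of like size to that of the chloro. Also open, going by these compounds, is whether the methylamino group would remain as close to the amino group without the chloro, and whether an ethyl or longer chain on that nitrogen would do the same.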